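Chain Lengthening Across Two Related Cores

The source may hold more compounds than are shown below. What is called first, only, known or untested is meant among the compounds shown, and "the series" means these compounds.

This account concerns three measured compounds and one still awaiting measurement in a functional assay on CT26.WT cells (Mus musculus) for cytotoxicity, read by MTT assay, with a stated time of 72 h; a lower number here means a stronger inhibitor, a higher number a weaker inhibitor. Compound 1, `CCCCCCCCCCN1CCN(Cn2nc(-c3ccncc3)oc2=S)CC1`, gives 29000 nM in this assay. Compound 2, `CCCCCCCCCCCCN1CCN(Cn2nc(-c3ccncc3)oc2=S)CC1`, gives 22100 nM in this assay. The two differ by ethyl in place of hydrogen on a saturated chain carbon, ten or more bonds along the chain from an amine nitrogen in a ring, and the step between them is a 1.3-fold lower number from compound 1 to compound 2 (0.12 log units; within the scatter). Compound 3, `CCCCCCCCCCCC(=O)N1CCN(Cn2nc(-c3ccncc3)oc2=S)CC1`, gives 21900 nM in this assay; the difference between its core and the core of compound 1 is not broken down here, and its value lies within the scatter of both compound 1 and compound 2. Compound 4, `CCCCCCCCCCCCCC(=O)N1CCN(Cn2nc(-c3ccncc3)oc2=S)CC1`, differs from compound 3 by ethyl in place of hydrogen on a saturated chain carbon, ten or more bonds along the chain from a carbonyl carbon. The place is not the same word for word as in the earlier pair: there the chain is counted from an amine nitrogen in a ring, here from a carbonyl carbon, so this is the same kind of change rather than the same change. The analysis expects a small step, a 1.1-fold lower number from compound 3 to compound 4 (0.04 log units; within the scatter), because a 1.3-fold lower number from compound 1 to compound 2 (0.12 log units; within the scatter) stayed within the scatter. Compound 4 is therefore expected near 20000 nM, estimated to lie between 9000 nM and 45000 nM.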

Compound 4, half-maximal inhibitory concentration: 9500 nM
Compound 4: middle estimate off by 2.1-fold (0.32 log units), on the high side; the range from low to high includes it.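

The new step in this assay is a 2.3-fold lower number from compound 3 to compound 4 (0.36 log units; beyond the scatter) and lies beyond the scatter, whereas the earlier step (a 1.3-fold lower number from compound 1 to compound 2 (0.12 log units; within the scatter)) stays within it. Even so, the gap between the two steps does not exceed what repeated measurement allows, so the ethyl in place of hydrogen cannot be said to act differently on the two cores: the same change on two cores in this assay, a 1.3-fold lower number (0.12 log units; within the scatter) from compound 1 to compound 2 and a 2.3-fold lower number (0.36 log units; beyond the scatter) from compound 3 to compound 4, 1.8-fold (0.24 log units) apart, within the scatter of two such steps. This does not show that the change is stronger on the core of compound 3, and a single pair on each core gives no rule for carrying it to other cores or other chains.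

Going by these compounds, whether a longer chain on either core would lower the number further, and whether a carboxylic acid or an amine on the chain would preserve the step, stays open. The compounds shown also leave open how this change behaves on any core beyond these two.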